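This account rests on a few compounds, and the source may have more. Where it says the series, first, only, none or still open, it means among the compounds named here.

Measured so far:
compound 1 `CNC(=O)c1ccccc1Oc1nc(Nc2ccccc2F)ncc1Br`: > 50000 nM (a limit)
compound 2 `CNC(=O)c1ccccc1Oc1nc(Nc2cccc(Br)c2)ncc1Br`: 49000 nM
compound 3 `CNC(=O)c1ccccc1Oc1nc(Nc2ccc(Cl)cc2F)ncc1Br`: > 50000 nM (a limit)

In a functional assay on U-937 cells (Homo sapiens) for antiproliferative activity, read by MTT assay, with a stated time of 24 h (on this read-out lower numbers stand for stronger inhibition and higher numbers for weaker inhibition), compound 1 gives > 50000 nM, which is a limit and not a number. It stands with compound 3 at the limit of > 50000 nM in this assay, at which 2 of the 3 values shown sit. Compound 2 is the only one of the three with a number.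

Compound 4 `CNC(=O)c1ccccc1Oc1nc(Nc2cccc(OC)c2)ncc1Br` carries one change from compound 1: 3-methoxyphenyl in place of 2-fluorophenyl on a nitrogen on an aromatic ring. The nearest measured change also replaces the 2-fluorophenyl, this time with 3-bromophenyl, and gives an at least 1.0-fold lower number from compound 1 to compound 2 (0.00 log units; that floor lies within the scatter). The other readable step, an at least 1.0-fold higher number from compound 2 to compound 3 (0.00 log units; that floor lies within the scatter), likewise has a floor within the scatter, while a step that the two limits leave unreadable from compound 1 to compound 3 cannot be sized. These limits hide the true size of the steps, but nothing measured points to a real gain or loss, so no step beyond the scatter is expected in this assay.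

The expected result is an at least 1.1-fold lower number from compound 1 to compound 4 (0.07 log units; that floor lies within the scatter). For compound 4 the estimated value is 42000 nM, with an expected range from 18000 nM to 75000 nM.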

Compound 4, half-maximal inhibitory concentration: 24300 nM
Beside the measured number, compound 4's estimate is 1.7-fold (0.24 log units) above it, and the stated range covers the measured number.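

In this assay, 3-methoxyphenyl on this nitrogen gives a step that clears the scatter, an at least 2.0-fold lower number from compound 1 to compound 4 (0.31 log units; beyond the scatter), and the same holds for the replacement of 4-chloro-2-fluorophenyl, an at least 2.0-fold lower number from compound 3 to compound 4 (0.31 log units; beyond the scatter). Methoxy in place of bromo on the aromatic carbon gives a 2.0-fold lower number from compound 2 to compound 4 (0.30 log units; within the scatter), so these two groups cannot be told apart in this assay. The two steps beyond the scatter give only floors, since compound 1 and compound 3 each stand at a limit and not at a number: the limit of > 50000 nM in this assay, at which 2 of the 4 values shown sit.

As far as these compounds go, the true size of those two steps remains open. From the compounds shown here alone, it also remains open whether a hydroxy group or an amine in place of the methoxy of compound 4 would change the number by more than the scatter.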